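Sulfonamide piperidine amides: varying the acyl substituent

The source may report more compounds than this note shows. Statements on the series, on what has been measured and on what is new or still open speak of the compounds shown alone.

Compound 1 `O=C(CN1CCNCC1)N1CCC(NS(=O)(=O)c2cc(S(=O)(=O)c3ccccc3)ccc2C(F)(F)F)CC1` and compound 2 `O=C(Cn1ccnc1)N1CCC(NS(=O)(=O)c2cc(S(=O)(=O)c3ccccc3)ccc2C(F)(F)F)CC1` share a core and differ only in the group on the carbonyl carbon of the acyl side chain. In a functional assay on U2OS cells for antagonist activity at proto-oncogene Wnt-3 (Homo sapiens), read by a luciferase reporter, with a stated time of 18 h (on this read-out lower numbers stand for an effect already at smaller amounts and higher numbers for an effect only at larger amounts of compound), compound 1 gives 250 nM, and compound 2 gives 230 nM. The step of a 1.1-fold lower number from compound 1 to compound 2 (0.04 log units; within the scatter) shows that exchanging one nitrogen heterocycle for another at this point left the read-out essentially unchanged. Compound 2 thus stands among the two measured numbers without being set apart from compound 1.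

Compound 3 `CC(C)(C)OC(=O)N1CCC[C@H]1C(=O)N1CCC(NS(=O)(=O)c2cc(S(=O)(=O)c3ccccc3)ccc2C(F)(F)F)CC1` carries a further variation at the same position: 1-(tert-butoxycarbonyl)pyrrolidin-2-yl in place of (1H-imidazol-1-yl)methyl on a carbonyl carbon. Going by the values given here, the only measured step that bears on this change is the one from compound 1 to compound 2, which was within the scatter; it speaks for some tolerance at the acyl position, but the incoming group is of a different kind from either heterocycle, so it gives only a weak guide. No step beyond the scatter is therefore expected, with a wide range allowed in either direction.

For compound 3 the expected value in this assay is 300 nM, with a range from 90 nM to 1200 nM. The expected change from compound 2 is a 1.3-fold higher number from compound 2 to compound 3 (0.12 log units; within the scatter).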

Compound 3, half-maximal effective concentration: 60 nM
The estimate for compound 3 lay 5.0-fold (0.70 log units) above the measured number; the measured number lies below the stated range.
By their numbers in this assay, from the lowest: compound 3; then compounds 2 and 1 (each within the scatter of the next).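

In this assay this position turns out to be more than tolerant: the read-out responds to the acyl group, with a 3.8-fold lower number from compound 2 to compound 3 (0.58 log units; beyond the scatter) and a 4.2-fold lower number from compound 1 to compound 3 (0.62 log units; beyond the scatter), whereas the two earlier nitrogen heterocycles could not be told apart. The entering 1-(tert-butoxycarbonyl)pyrrolidin-2-yl differs from (1H-imidazol-1-yl)methyl in several counted features at once (12 heavy atoms against 6, a non-aromatic ring for an aromatic one, 1 double bond outside aromatic rings and 1 defined stereocentre), so this step does not assign the lower number to any one of them. Nothing on hand accounts for the shift in the read-out.

Open, on these data alone, is which part of the entering group carries the step: the free pyrrolidine amine, an acetyl group on the ring nitrogen in place of tert-butoxycarbonyl, or the opposite configuration at the stereocentre would each separate one feature from the others. Also open, as far as these compounds go, is how far the position extends beyond rings, for instance with a plain longer alkyl chain or a carboxylic acid on the carbonyl carbon.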